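Adding a methoxy to compound 2: cytotoxicity expectation

The compounds below may be only part of what the source reports. "The series", "measured", "known", "first", "only" and "open" are said of these compounds alone.

Three compounds sharing one core were tested in an ADME assay on THP-1 cells (Homo sapiens) for cytotoxicity; on this read-out lower numbers stand for stronger inhibition and higher numbers for weaker inhibition. Compound 1 `COc1ccccc1-c1nnc(-c2ccc(C(=O)N/N=C/c3cccc(F)c3)cc2)o1` gives 353000 nM, compound 2 `COc1ccccc1-c1nnc(-c2ccc(C(=O)N/N=C/c3ccccc3O)cc2)o1` gives 207000 nM, and compound 3 `COc1ccccc1-c1nnc(-c2ccc(C(=O)N/N=C/c3ccccc3F)cc2)o1` gives 313000 nM. Compound 2 carries the lowest of the three numbers, yet the steps of a 1.7-fold lower number from compound 1 to compound 2 (0.23 log units; within the scatter) and a 1.5-fold higher number from compound 2 to compound 3 (0.18 log units; within the scatter) both lie within the scatter, as does a 1.1-fold lower number from compound 1 to compound 3 (0.05 log units; within the scatter), so no order among them can be claimed. Compound 4 `COc1ccc(/C=N/NC(=O)c2ccc(-c3nnc(-c4ccccc4OC)o3)cc2)c(O)c1` differs from compound 2 in one place: methoxy in place of hydrogen on an aromatic carbon. For the measured compounds named here, no measured step involves a methoxy group, so none bears directly on this change; every measured step has stayed within the scatter. Compound 4 is therefore expected to show a step of a 1.1-fold higher number from compound 2 to compound 4 (0.03 log units; within the scatter) that stays within the scatter. The estimate for compound 4 is 220000 nM, with a range from 110000 nM to 440000 nM.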

Compound 4, half-maximal inhibitory concentration: 308000 nM
The estimate for compound 4 lay 1.4-fold (0.15 log units) below the measured number, within the range that was stated.
By their numbers in this assay, from the lowest: compounds 2, 4, 3 and 1 (each within the scatter of the next).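

The first methoxy in the series, meta to a hydroxy group and para to a large group, gives a 1.5-fold higher number from compound 2 to compound 4 (0.17 log units; within the scatter) in this assay, so this place accepts the added group without a shift beyond the scatter. The 2-hydroxy-4-methoxyphenyl group also stays within the scatter of both fluorophenyl groups, with a 1.0-fold lower number from compound 3 to compound 4 (0.01 log units; within the scatter) and a 1.1-fold lower number from compound 1 to compound 4 (0.06 log units; within the scatter). Nothing available explains these numbers. On these data alone, whether an amine, a carboxylic acid or a longer chain at this place would go beyond the scatter remains open. So does whether methoxy would behave alike without the hydroxy group.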